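Amide for Acid: Expected Tolerability of Compound 3

The source may report more compounds than this note shows. Statements on the series, on what has been measured and on what is new or still open speak of the compounds shown alone.

Measured compounds:
Compound 1 `COC(=O)NC1=CS(=O)(=O)O[C@@]12[C@@H](CO[Si](C)(C)C(C)(C)C)O[C@@H](n1cc(C)c(=O)n(C)c1=O)[C@@H]2O[Si](C)(C)C(C)(C)C`: in a functional assay on HEL cells (Homo sapiens) for cytotoxicity, read by microscopy (a lower number here means that less compound is tolerated, a higher number that more compound is tolerated), compound 1 gives >= 50000 nM, which is a limit of the assay and not a number.
Compound 2 `Cc1cn([C@@H]2O[C@H](CO[Si](C)(C)C(C)(C)C)[C@@]3(OS(=O)(=O)C=C3NCC(=O)O)[C@H]2O[Si](C)(C)C(C)(C)C)c(=O)n(C)c1=O`: in this assay compound 2 gives 300000 nM.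

Among the compounds with values here, compound 2 carries the only plain number among the two values shown, so it cannot be ranked against compound 1 on these data. Within the data shown here, the only measured step, a step that the limit leaves unreadable from compound 1 to compound 2, has no readable size, because the limit of >= 50000 nM in this assay, at which 1 of the 2 values shown sits, sits on one side of it. Compound 3 `Cc1cn([C@@H]2O[C@H](CO[Si](C)(C)C(C)(C)C)[C@@]3(OS(=O)(=O)C=C3NCC(N)=O)[C@H]2O[Si](C)(C)C(C)(C)C)c(=O)n(C)c1=O` differs from compound 2 in one place: amino in place of hydroxy on a carbonyl carbon. Among the measured compounds shown here, no measured step with a readable size bears on this change, so the expectation rests on compound 2 alone, and the change is small in the sense counted above, one heavy atom exchanged for one. The step from compound 2 to compound 3 in this assay is therefore expected to be a 1.5-fold lower number from compound 2 to compound 3 (0.18 log units; within the scatter), within the usual scatter. Compound 3 is estimated at 200000 nM, with a range from 50000 nM to 500000 nM, and a fair chance that only a limit is reported.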

Compound 3, minimum cytotoxic concentration: 16000 nM
Estimate against measurement, compound 3: 13-fold (1.10 log units) above; the whole stated range lies above it.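

On a carbonyl carbon whose other neighbour is a saturated chain carbon, exchanging hydroxy for amino swaps only one heavy atom for one, yet in this assay this carboxy to carbamoyl change gives a 19-fold lower number from compound 2 to compound 3 (1.27 log units; beyond the scatter). So in this pair, a very small edit at this place makes a large difference to how much compound the cells tolerate. The amide also provides the first readable comparison with the methoxycarbonyl compound, an at least 3.1-fold lower number from compound 1 to compound 3 (0.49 log units; beyond the scatter), whereas the step between compound 1 and compound 2 cannot be read, because the value of compound 1 is a limit: the limit of >= 50000 nM in this assay, at which 1 of the 3 values shown sits.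

The compounds shown do not settle whether the lower number comes from the presence of the amino group or from the absence of the hydroxy group, as this is a single exchange in a single pair. A methyl ester, a methylamide or a longer chain ending in carboxy or carbamoyl would help show whether the effect is specific to the carbamoylmethyl group or extends to other groups on this nitrogen.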